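The source may report more compounds than this note shows. Statements on the series, on what has been measured and on what is new or still open speak of the compounds shown alone.

Compound 2 `COCCn1c(Cc2cc(OC)c(OC)c(OC)c2)nc2c(N)ncnc21` gives 64600 nM in a functional assay on MCF7 cells (Homo sapiens) for antiproliferative activity (on this read-out lower numbers stand for stronger inhibition and higher numbers for weaker inhibition), the highest of the two numbers recorded so far; the nearest is compound 1 `COc1cc(Cc2nc3c(N)nc(F)nc3n2CC2CCCO2)cc(OC)c1OC`, which gives 22900 nM in this assay, a gap beyond the scatter. Compound 1 and compound 2 differ in more than one place, so that gap is not assigned to any single change. Compound 3 `COCCn1c(Cc2cc(OC)c(OC)c(OC)c2)nc2c(N)nc(F)nc21` carries fluoro in place of hydrogen on an aromatic carbon. Going by the values given here, no step of this kind has been measured; a modest move toward a lower number is expected, with the step of a 1.8-fold lower number from compound 2 to compound 3 (0.27 log units; within the scatter) possibly still within the scatter. Compound 3 is estimated at 35000 nM, within a range from 12000 nM to 100000 nM.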

Compound 3, half-maximal inhibitory concentration: 64600 nM
For compound 3 the middle estimate is 1.8-fold (0.27 log units) below the measured one, within the range that was stated.
By their numbers in this assay, from the lowest: compound 1; then compounds 2 and 3 (each within the scatter of the next).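

In this assay fluoro in place of hydrogen on the aromatic carbon between two ring nitrogen atoms gives no change at the digits printed from compound 2 to compound 3 (within the scatter), so this position tolerates the change without a readable shift. Going by these compounds alone, with fluoro held constant, methoxymethyl in place of oxolan-2-yl on the saturated chain carbon gives a 2.8-fold higher number from compound 1 to compound 3 (0.45 log units; beyond the scatter), the only step here beyond the scatter. No evidence on the reason for either step is available.

On these data alone, whether a chloro group or an amine on that aromatic carbon would shift the number remains open. So does whether a longer chain in place of methoxymethyl would do so.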